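A few compounds are considered here, and "the series" means these few. Any claim that something is new, unique, unknown or untested is made for them only; others in the source may bear on it.

Measured in an ADME assay on MT4 cells (Homo sapiens) for cytotoxicity, read by XTT assay, with a stated time of 5 days; a lower number here means that less compound is tolerated, a higher number that more compound is tolerated:
- compound 1 `COC(=O)N[C@H](C(=O)NN(CC[C@@](O)(Cc1ccccc1)C(=O)N[C@H]1c2ccccc2C[C@H]1O)Cc1ccc(-c2ccccn2)cc1)C(C)(C)C`: > 10000 nM
- compound 2 `COC(=O)N[C@H](C(=O)NN(CC[C@@](O)(Cc1ccccc1)C(=O)N[C@H]1c2ccccc2C[C@H]1O)Cc1ccc(-c2cccnc2)cc1)C(C)(C)C`: 4900 nM

Compound 1 gives > 10000 nM, which is a limit of the assay and not a number. Going by the values given here, compound 2, at 4900 nM, holds the only actual number so far.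

The next step leads to compound 3 `COC(=O)N[C@H](C(=O)NN(CC[C@@](O)(Cc1ccccc1)C(=O)N[C@H]1c2ccccc2C[C@H]1O)Cc1ccc(-c2cc(F)cc(F)c2)cc1)C(C)(C)C`: 3,5-difluorophenyl in place of pyridin-3-yl on an aromatic carbon. Here 3,5-difluorophenyl takes the place of pyridin-3-yl, para to a large group.

Among the compounds with values here, one measured step bears on this position: an at least 2.0-fold lower number from compound 1 to compound 2 (0.30 log units; that floor lies within the scatter). Compound 1 enters that step only through (the limit of > 10000 nM in this assay, at which 1 of the 2 values shown sits), which is a limit. That step involves no fluorinated group, so it gives weak guidance, and no change beyond the scatter is expected in this assay, in either direction. The expected step is a 1.0-fold higher number from compound 2 to compound 3 (0.01 log units; within the scatter). For compound 3 the estimated value is 5000 nM, with an expected range of 2200 nM to 11000 nM.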

Compound 3, half-maximal cytotoxic concentration: > 10000 nM
Compound 3 was reported as a limit; the forecaster's own chance of this, stated with the estimate: 30%; middle value at least 2.0-fold (0.30 log units) away from the limit.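

In this assay compound 3 gives > 10000 nM, which is a limit of the assay and not a number. Putting 3,5-difluorophenyl in place of pyridin-3-yl gives an at least 2.0-fold higher number from compound 2 to compound 3 (0.30 log units; that floor lies within the scatter), while the step between compound 1 and compound 3 cannot be read. The position, on an aromatic carbon para to a large group, now carries a fluorinated ring of carbon only as well as two pyridyl rings, and two of the three compounds end at the same limit: the limit of > 10000 nM in this assay, at which 2 of the 3 values shown sit.

On these data alone, whether the pyridin-3-yl ring of compound 2 truly differs from the other two rings stays open, since the floors of its steps lie within the scatter. Also open, as far as these compounds go, is how an aminomethyl group or a carboxylic acid on this ring would read in this assay.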